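The compounds below may be only part of what the source reports. "The series", "measured", "known", "first", "only" and "open" are said of these compounds alone.

Compound 1 `COCC(=N)NCCC[C@H](N)C(=O)O`: 75%
Compound 2 `COCC(=N)NCCCCN`: 42%
Compound 3 `COCCC(=N)NCCC[C@H](N)C(=O)O`: 50%

In an assay on isolated protein for inhibition of Nitric oxide synthase, inducible (Homo sapiens), read by spectrophotometry, using NADPH, tested at 1 mM, in the presence of a further agent that is not named here (on this read-out lower numbers stand for less inhibition and higher numbers for more inhibition at the one concentration tested (going by the name of the read-out)), compound 3 stands second highest of these three numbers: its gap to compound 2 lies within the scatter of repeated measurements, while the step of a number 25 percentage points lower from compound 1 to compound 3 (beyond the scatter) separates it from the highest value by more than the scatter. Compound 4 `COCCC(=N)NCCCCN` differs from compound 3 by hydrogen in place of carboxy on a saturated chain carbon bound to an amine nitrogen and a saturated chain carbon. Exactly this change has been seen once already in the series, and there it produced a number 33 percentage points lower from compound 1 to compound 2 (beyond the scatter), a large drop. A drop of comparable size is therefore expected here. Compound 4 is estimated to show a number 30 percentage points lower from compound 3 to compound 4 (beyond the scatter), arriving at an expected 20%, with a likely range from 5% to 38%.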

Compound 4, a percentage reported as inhibition, at one concentration (the size of the read-out at that concentration, not a potency): 16%
Compound 4: the middle estimate sits 4 percentage points above what was measured, within the range that was stated.
By their numbers in this assay, from the lowest: compound 4; then compounds 2 and 3 (each within the scatter of the next); then compound 1.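

Hydrogen in place of carboxy now gives a number 34 percentage points lower from compound 3 to compound 4 (beyond the scatter) in this assay, so the loss seen earlier recurs on a second core: the same change on two cores in this assay, a number 33 percentage points lower (beyond the scatter) from compound 1 to compound 2 and a number 34 percentage points lower (beyond the scatter) from compound 3 to compound 4, 1 percentage points apart, within the scatter of two such steps.
Methoxymethyl in place of methoxy likewise gives a number 26 percentage points lower from compound 2 to compound 4 (beyond the scatter) on the core without carboxy: the same change on two cores in this assay, a number 25 percentage points lower (beyond the scatter) from compound 1 to compound 3 and a number 26 percentage points lower (beyond the scatter) from compound 2 to compound 4, 1 percentage points apart, within the scatter of two such steps.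
Across these four compounds, each change therefore keeps its size whether or not the other is present.

Going by these compounds, whether this holds for other replacements at that carbon, such as a methyl ester or an amide in place of carboxy, remains open. So does the effect of a longer group such as ethoxymethyl in place of methoxy.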